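Compound 3: methoxy in place of fluoro

This account rests on a few compounds, and the source may have more. Where it says the series, first, only, none or still open, it means among the compounds named here.

Measured in a physicochemical assay for lipophilicity, read by HPLC, at pH 7.5; on this read-out higher numbers stand for higher lipophilicity and lower numbers for lower lipophilicity:
Compound 1 `CC[C@@H](Nc1c(C#N)c(-c2ccc(-c3cccc(C)c3)cc2)nc2cnccc12)C(N)=O`: 3
Compound 2 `CC[C@@H](Nc1c(C#N)c(-c2ccc(-c3ccc(F)cc3)cc2)nc2cnccc12)C(N)=O`: 2.7

Compound 2, at 2.7, stands within the scatter of compound 1, so the two numbers cannot be told apart. Compound 3 `CC[C@@H](Nc1c(C#N)c(-c2ccc(-c3ccc(OC)cc3)cc2)nc2cnccc12)C(N)=O` has not been measured and differs from compound 2 by one group: methoxy in place of fluoro on an aromatic carbon. This is methoxy in place of fluoro on an aromatic carbon, para to a large group. Among the compounds with values here, the one measured step that bears on it is a number 0.30 log units lower from compound 1 to compound 2 (within the scatter), with 4-fluorophenyl in place of 3-methylphenyl on an aromatic carbon. Resting on that single step to compound 2, no step beyond the scatter is expected in this assay. The estimated step is a number 0.10 log units higher from compound 2 to compound 3 (within the scatter). Compound 3 is expected at 2.8, with an estimated range from 2.4 to 3.2.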

Compound 3, distribution coefficient: 2.7
Compound 3: middle estimate off by 0.10 log units, on the high side; the range from low to high includes it.
By their numbers in this assay, from the lowest: compounds 2, 3 and 1 (each within the scatter of the next).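

In this assay, methoxy in place of fluoro on the six-membered aromatic ring of carbon only, para to a large group, gives no change at the digits printed from compound 2 to compound 3 (within the scatter), so a group carrying a hydrogen-bond acceptor that fluoro lacks leaves no readable change at this position. With 4-methoxyphenyl in place of 3-methylphenyl, the read-out shows a number 0.30 log units lower from compound 1 to compound 3 (within the scatter), which places all three compounds shown within the scatter of one another. Nothing at hand gives a reason for this flat result.

The compounds shown leave open whether an amine, a carboxylic acid or a longer chain such as ethoxy at this same place would move the number beyond the scatter. They also leave open whether any change at this position would show up in a read-out other than this assay.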